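From methoxycarbonyl to ethyl: what compound 4 may show

The source may report more compounds than this note shows. Statements on the series, on what has been measured and on what is new or still open speak of the compounds shown alone.

compound 1 `COC(=O)Cn1c(=O)c(S(=O)(=O)c2ccc(F)cc2F)cc2cnc(Nc3ccc4[nH]ccc4c3)nc21` gives 10000 nM
compound 2 `COc1ccc(Nc2ncc3cc(S(=O)(=O)c4ccc(C)cc4)c(=O)n(C)c3n2)cc1` gives 100000 nM
compound 3 `Cn1c(=O)c(C(=O)Nc2ccc(F)cc2F)cc2cnc(Nc3ccc4[nH]ccc4c3)nc21` gives 5000 nM

All three numbers come from a functional assay on DU-145 cells (Homo sapiens) for inhibition, read by trypan blue exclusion, with a stated time of 72 h; on this read-out higher numbers stand for weaker inhibition and lower numbers for stronger inhibition. Compound 1, at 10000 nM, lies within the usual scatter of compound 3, at 5000 nM, so these two cannot be ranked against each other. Compound 2, at 100000 nM, gives a higher number than compound 1, by a margin beyond the scatter, and so shows weaker inhibition.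

The next compound to be tested is compound 4 `CCCn1c(=O)c(S(=O)(=O)c2ccc(F)cc2F)cc2cnc(Nc3ccc4[nH]ccc4c3)nc21`. It keeps the core of compound 1 and carries ethyl in place of methoxycarbonyl on a saturated chain carbon bound to an aromatic nitrogen. Cut one bond further out, the same difference reads (methoxycarbonyl)methyl to propyl.

Going by the values given here, no two measured compounds differ in one place only, so the data hold no direct precedent for this change. Compound 3, at 5000 nM, differs from compound 1 in more than one place and still stays within the scatter of it. In this assay, then, no step beyond the scatter is expected. The expected step is a 1.3-fold lower number from compound 1 to compound 4 (0.10 log units; within the scatter). For compound 4 the estimated value is 8000 nM, with an expected range from 2500 nM to 30000 nM.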

Compound 4, half-maximal inhibitory concentration: 1000 nM
The estimate for compound 4 lay 8.0-fold (0.90 log units) above the measured number; measured number outside the range, below it.
By their numbers in this assay, from the lowest: compound 4; then compounds 3 and 1 (each within the scatter of the next); then compound 2.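

In this assay, ethyl in place of methoxycarbonyl on a saturated chain carbon bound to an aromatic nitrogen brings a 10-fold lower number from compound 1 to compound 4 (1.00 log units; beyond the scatter), the first step among the compounds shown that isolates a change in one place. It shows that this position is not indifferent to what it carries: the read-out responds beyond the scatter when (methoxycarbonyl)methyl gives way to propyl, a change that swaps a group with a double bond and hydrogen-bond acceptors for one with neither. No measurement among the compounds shown bears on why this step occurs, so it stands as an observation only.

As far as these compounds go, a single step cannot separate the departure of methoxycarbonyl from the arrival of ethyl, so it remains open which of the two goes with the lower number. Also open, from the compounds shown here alone, is how a longer chain, a carboxylic acid or an amine on the same saturated chain carbon would read in this assay, and whether the same change would give a step of similar size on the core of compound 3 or compound 2.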